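Swapping Hydroxy for Chloro on the Aryl Ketone Ring

The source may hold more compounds than are shown below. What is called first, only, known or untested is meant among the compounds shown, and "the series" means these compounds.

Compound 2 `O=C(/C=C/c1cc2ccccc2[nH]c1=O)c1ccc(O)cc1` stands level with compound 1 `COc1ccc(C(=O)/C=C/c2cc3ccccc3[nH]c2=O)cc1`: in a functional assay on U-251 cells (Homo sapiens) for cytotoxicity, read by sulforhodamine B assay, with a stated time of 24 h (a higher number here means a weaker inhibitor of growth, a lower number a stronger inhibitor of growth), compound 2 gives 10900 nM, and compound 1 gives 10900 nM. For the measured compounds named here, the only step measured so far, no change at the digits printed from compound 1 to compound 2 (within the scatter), altered the group on that same ring and left the number where it was. Compound 3 `O=C(/C=C/c1cc2ccccc2[nH]c1=O)c1ccc(Cl)cc1` carries the next change on that ring: chloro in place of hydroxy on an aromatic carbon. Going by the values given here, with that single flat step as the only guide, the expected change from compound 2 to compound 3 in this assay is small, a 1.1-fold lower number from compound 2 to compound 3 (0.06 log units; within the scatter), in no clear direction. Compound 3 is therefore estimated at 9500 nM, within a range from 3500 nM to 26000 nM.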

Compound 3, concentration for total growth inhibition: 11400 nM
The estimate for compound 3 lay 1.2-fold (0.08 log units) below the measured number; the measured number falls inside the stated range.
By their numbers in this assay, from the lowest: compounds 1, 2 and 3 (each within the scatter of the next).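

At this place on the ring, para to a large group, this assay gives a 1.0-fold higher number from compound 2 to compound 3 (0.02 log units; within the scatter) for chloro in place of hydroxy and a 1.0-fold higher number from compound 1 to compound 3 (0.02 log units; within the scatter) for chloro in place of methoxy. Hydroxy, with a hydrogen-bond donor and acceptor, and chloro, with neither, therefore read alike across these three compounds. Nothing available accounts for this flat result. The compounds shown leave open whether an amine, a carboxylic acid or a longer chain at this place would move the number.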